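Trimming the side chain: from compound 2 to compound 3

A few compounds are considered here, and "the series" means these few. Any claim that something is new, unique, unknown or untested is made for them only; others in the source may bear on it.

Measured so far:
compound 1, `NCCCC[C@H](NC(=O)CN(c1nc(Cl)nc2[nH]cnc12)C1CC1)C(=O)O`, 28.8%
compound 2, `CC(C)[C@H](NC(=O)CN(c1nc(Cl)nc2[nH]cnc12)C1CC1)C(=O)O`, 30.3%

Going by the values given here, compound 2, `CC(C)[C@H](NC(=O)CN(c1nc(Cl)nc2[nH]cnc12)C1CC1)C(=O)O`, stands at the top of the two numbers in a functional assay on the whole organism (Tail, strain ICR) with Mus musculus as the target, in the tail flick test, with a stated time of 90 min, at a dose of 25 umol/kg by the oral route (a higher number here means a stronger effect of the compound at the dose given, a lower number a weaker effect), where compound 2 gives 30.3%; the only other measured compound, compound 1, `NCCCC[C@H](NC(=O)CN(c1nc(Cl)nc2[nH]cnc12)C1CC1)C(=O)O`, gives 28.8%, and the step of a number 1.5 percentage points higher from compound 1 to compound 2 (within the scatter) lies within the scatter, so the two cannot be ranked.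

Compound 3, `C[C@H](NC(=O)CN(c1nc(Cl)nc2[nH]cnc12)C1CC1)C(=O)O`, is not yet measured. It differs from compound 2 by methyl in place of isopropyl on a saturated chain carbon bound to an amide-type nitrogen and a carbonyl carbon.

Among the compounds with values here, the single step known so far, a number 1.5 percentage points higher from compound 1 to compound 2 (within the scatter), touches the same saturated chain carbon bound to an amide-type nitrogen and a carbonyl carbon, exchanging one side chain for another without moving the number beyond the scatter. Nothing else is known about this position. On that basis the step from compound 2 to compound 3 is expected to be small, a number 1.3 percentage points lower from compound 2 to compound 3 (within the scatter), with no direction beyond the scatter. Compound 3 is therefore estimated at 29%, within a range from 15% to 43%.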

Compound 3, a percentage reported as activity, at one dose (the size of the read-out at that dose, not a potency): 43.5%
The estimate for compound 3 lay 14.5 percentage points below the measured number, outside the stated range (above it).
By their numbers in this assay, from the lowest: compounds 1 and 2 (each within the scatter of the next); then compound 3.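

The position is not indifferent in this assay after all: methyl in place of isopropyl on a saturated chain carbon bound to an amide-type nitrogen and a carbonyl carbon gives a number 13.2 percentage points higher from compound 2 to compound 3 (beyond the scatter) and the comparison with the 4-aminobutyl side chain gives a number 14.7 percentage points higher from compound 1 to compound 3 (beyond the scatter) as well. Compound 1 and compound 2 could not be ranked, so among these three compounds only the methyl side chain stands apart, and the two larger side chains, one with an amine and one without, give no order of their own. The data shown offer no measured explanation for this rise.

From the compounds shown here alone, whether the rise is particular to methyl stays open, since ethyl or hydroxymethyl on this carbon, or hydrogen in place of the methyl, would show whether the number keeps climbing, levels off or falls back. Going by these compounds, all three compounds also carry the same carboxylic acid and were read at a single dose and time, so it remains open how a methyl ester in its place would behave and whether the step from isopropyl to methyl would hold at other doses.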